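Solubility of a benzoxazolone propanoic acid: chloro for cyclopropylmethoxy

The source may hold more compounds than are shown below. What is called first, only, known or untested is meant among the compounds shown, and "the series" means these compounds.

Compound 1: `CCOc1cc2oc(=O)n(CCC(=O)O)c2cc1Cl` — > 1880 ug/mL
Compound 2: `O=C(O)CCn1c(=O)oc2cc(OCC3CC3)c(Cl)cc21` — > 2060 ug/mL
Compound 3: `O=C(O)CCn1c(=O)oc2cc(Cl)c(Cl)cc21` — not yet measured

Of the compounds shown here, two have been measured in a physicochemical assay for solubility, with a stated time of 24 h; on this read-out higher numbers stand for higher solubility and lower numbers for lower solubility. For compound 1 the read-out is a limit of the assay, (the limit of > 1880 ug/mL in this assay, at which 1 of the 2 values shown sits), and not a number. For compound 2 the read-out is likewise a limit of the assay, (the limit of > 2060 ug/mL in this assay, at which 1 of the 2 values shown sits). Among the measured compounds shown here, the only measured step, a step that the two limits leave unreadable from compound 1 to compound 2, is therefore unreadable in size, and compound 2 stands at a limit with nothing measured beyond it.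

Compound 3 differs from compound 2 by the change (chloro in place of cyclopropylmethoxy on an aromatic carbon). For the measured compounds named here, no measured step speaks to this kind of change, and the step between compound 1 and compound 2 gives no readable size, so nothing here supports an expectation of either direction beyond the scatter. Compound 3 is expected to remain highly soluble, with a step from compound 2 of roughly an at least 1.7-fold lower number from compound 2 to compound 3 (0.23 log units; that floor lies within the scatter), which rests on no measured evidence. Compound 3 is estimated at 1200 ug/mL, with a range from 300 ug/mL to 2500 ug/mL, and a real chance that this assay again reports only a limit.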

Compound 3, solubility: 270 ug/mL
For compound 3 the middle estimate is 4.4-fold (0.65 log units) above the measured one, outside the stated range (below it).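

In this assay, among the compounds shown here, this aromatic carbon ortho to a chloro group gives the first readable steps: chloro in place of cyclopropylmethoxy gives an at least 7.6-fold lower number from compound 2 to compound 3 (0.88 log units; beyond the scatter), and chloro in place of ethoxy gives an at least 6.9-fold lower number from compound 1 to compound 3 (0.84 log units; beyond the scatter). While the two compounds with an ether group at this place left the step between them unreadable, compound 3, with chloro there, gives a number rather than a limit, so both new steps can be stated only as minimum sizes, because the read-out of compound 1 is a limit: the limit of > 1880 ug/mL in this assay, at which 1 of the 3 values shown sits. The same holds because the read-out of compound 2 is also a limit: the limit of > 2060 ug/mL in this assay, at which 1 of the 3 values shown sits.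

Going by these compounds, the true size of either step remains open, as does whether the difference between ethoxy and cyclopropylmethoxy would matter once both could be read as numbers. The compounds shown also do not tell whether a methoxy, a hydroxyl, a methyl or an amine on this carbon would give a read-out at a limit or one nearer that of compound 3, or how a longer chain bearing the carboxylic acid would behave.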